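Exchanging a dichlorophenyl for an iodophenyl on the sulfonyl

This account rests on a few compounds, and the source may have more. Where it says the series, first, only, none or still open, it means among the compounds named here.

Measured so far:
compound 1, `O=C(c1ccccc1)c1ccc(NS(=O)(=O)c2ccc(Cl)cc2Cl)cc1`: 82%
compound 2, `Cc1ccc(S(=O)(=O)Nc2cccc(C(=O)c3ccccc3)c2)cc1`: 34%

Of the compounds shown here, two have been measured in an assay on CHO cells for binding affinity to integrin alpha-1 (Homo sapiens), read by WST assay, with a stated time of 2 h, tested at 50 uM; a higher number here means more inhibition at the concentration tested (going by the name of the read-out), a lower number less inhibition. Compound 1 has the higher of the two numbers; compound 2 comes in lower, and the gap between them is beyond the usual scatter. Among the compounds with values here, no single-point step connects these two compounds, so their values can only be set side by side.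

Compound 3, `O=C(c1ccccc1)c1ccc(NS(=O)(=O)c2ccc(I)cc2)cc1`, has not yet been measured. It differs from compound 1 in one place: 4-iodophenyl in place of 2,4-dichlorophenyl on a sulfonyl sulfur. Within the data shown here, since no comparable step is available among the measured compounds, the expected size of the step rests on the standing of compound 1 alone. A modest loss of inhibition is expected for compound 3, with the step of a number 17 percentage points lower from compound 1 to compound 3 (beyond the scatter) taken as the likely outcome. On that basis compound 3 is estimated at 65%, with a range from 35% to 90%.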

Compound 3, a percentage reported as inhibition, at one concentration (the size of the read-out at that concentration, not a potency): 85%
Compound 3: the middle estimate sits 20 percentage points below what was measured, and the stated range covers the measured number.
By their numbers in this assay, from the lowest: compound 2; then compounds 1 and 3 (each within the scatter of the next).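

In this assay, the change of 4-iodophenyl in place of 2,4-dichlorophenyl on a sulfonyl sulfur gives a number 3 percentage points higher from compound 1 to compound 3 (within the scatter) and so leaves the read-out unchanged within the scatter. This position therefore accepts a single iodine on the phenyl ring, with both chlorines gone, without a measurable cost at the one concentration tested. Nothing available explains why the two groups read alike.

The compounds shown leave open whether a smaller 4-chlorophenyl or an unsubstituted phenyl would hold the same level, since two atoms changed identity and number in this one exchange. They also leave open whether the position accepts a phenyl ring bearing an amine or a carboxylic acid, or a non-aromatic group such as a longer alkyl chain.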